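Replacing an acetylpiperazine amide with a tert-butyl group

The source may hold more compounds than are shown below. What is called first, only, known or untested is meant among the compounds shown, and "the series" means these compounds.

Of the compounds shown here, three sharing one core have been tested in a physicochemical assay for solubility, at pH 7; a higher number here means a more soluble compound, a lower number a less soluble compound. Compound 1 `CC(=O)N1CCN(C(=O)N2Cc3c(NC(=O)c4ccc(F)cc4)n[nH]c3C2(C)C)CC1` returns only a limit of the assay in this assay, > 225000 nM, so its true solubility is known only as lying at or beyond that edge (the limit of > 225000 nM in this assay, at which 1 of the 3 values shown sits). Compound 2 `CN1CCC(C(=O)N2Cc3c(NC(=O)c4ccc(C(F)(F)F)cc4)n[nH]c3C2(C)C)CC1` gives 191000 nM in this assay. Going by the values given here, compound 3 `CC1(C)c2[nH]nc(NC(=O)c3ccc(F)cc3)c2CN1C(=O)N1CCN(c2ccccc2)CC1` gives 55000 nM in this assay, and the single measured step that changes one place, an at least 4.0-fold lower number from compound 1 to compound 3 (0.61 log units; beyond the scatter), is a drop beyond the scatter.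

The new compound 4 `CC(C)(C)C(=O)N1Cc2c(NC(=O)c3ccc(F)cc3)n[nH]c2C1(C)C` differs from compound 1 by tert-butyl in place of 4-acetylpiperazin-1-yl on a carbonyl carbon. The group that leaves carries the ring with two hetero atoms and the one hydrogen-bond acceptor; the tert-butyl that enters carries neither a ring nor any acceptor. Among the compounds with values here, no measured step makes exactly this exchange, so the only guide is the step from compound 1 to compound 3, where removing the acetyl in favour of phenyl lowered the number in this assay by a modest amount. A change of the same kind and a drop in the same direction is therefore expected here, an at least 5.6-fold lower number from compound 1 to compound 4 (0.75 log units; beyond the scatter), though its exact size is uncertain. Compound 4 is estimated at 40000 nM in this assay, within a range from 10000 nM to 150000 nM.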

Compound 4, solubility: 235000 nM
Compound 4: the middle estimate sits 5.9-fold (0.77 log units) below what was measured, outside the stated range (above it).
By their numbers in this assay, from the lowest: compound 3; then compounds 2 and 4 (each within the scatter of the next).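

In this assay no size can be read for the step from compound 1 to compound 4 because compound 1 stands at a limit of the assay and not at a number: the limit of > 225000 nM in this assay, at which 1 of the 4 values shown sits. The compounds shown leave open whether tert-butyl in place of 4-acetylpiperazin-1-yl raises the number, lowers it or leaves it within the scatter.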